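Swapping a chloro for a phenyl on the aryl tail

The source may report more compounds than this note shows. Statements on the series, on what has been measured and on what is new or still open speak of the compounds shown alone.

Three compounds share a core built on a citrate-like backbone with a sulfur-linked carbon chain that ends in an aromatic ring. Compound 1 `O=C(O)CC(O)(CSCCCCCCc1ccccc1Cl)C(=O)O` carries a chloro on that ring; compound 2 `O=C(O)CC(O)(CSCCCCCCc1ccc(F)cc1)C(=O)O` carries a fluoro instead. In an assay on isolated protein for inhibition of ATP-citrate synthase (Rattus norvegicus) (on this read-out higher numbers stand for weaker inhibition and lower numbers for stronger inhibition), compound 1 gives 69000 nM, and compound 2 gives 120000 nM. Compound 1 shows the lower of the two numbers, but the step of a 1.7-fold higher number from compound 1 to compound 2 (0.24 log units; within the scatter) stays within the scatter, so the two compounds cannot be told apart on this read-out.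

Compound 3 `O=C(O)CC(O)(CSCCCCCCc1ccccc1-c1ccccc1)C(=O)O` differs from compound 1 by phenyl in place of chloro on an aromatic carbon. Within the data shown here, only the step from compound 1 to compound 2 bears on this change, and it was within the scatter, so it gives no sign that altering the group on the aromatic ring moves the number much. Phenyl is a larger group than either halogen, which widens the uncertainty. Compound 3 is therefore expected to lie near compound 1, with an estimated step of a 1.3-fold lower number from compound 1 to compound 3 (0.10 log units; within the scatter), giving an expected value of 55000 nM in a range from 15000 nM to 200000 nM.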

Compound 3, inhibition constant: 18000 nM
Estimate against measurement, compound 3: 3.1-fold (0.49 log units) above; measured number inside the range.
By their numbers in this assay, from the lowest: compound 3; then compounds 1 and 2 (each within the scatter of the next).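

In this assay, among these compounds, the change from chloro to phenyl on this aromatic carbon gives a 3.8-fold lower number from compound 1 to compound 3 (0.58 log units; beyond the scatter) and is the first step in this set that lies beyond the scatter. The earlier pair could not show that the group on the aromatic ring can move the number at all, whereas this step shows that it can, though the size of the step is modest. Phenyl brings six heavy atoms and a whole aromatic ring where chloro had one heavy atom, yet nothing measured here explains why this exchange goes with the lower number.

The compounds shown leave open whether an aromatic ring is needed at this place or whether another group would do the same, as a cyclohexyl group, a pyridyl ring or an amine on the same aromatic carbon would tell. They also leave open whether phenyl at this place would give a step of similar size if a longer chain joined the ring to the sulfur.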